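The source may hold more compounds than are shown below. What is called first, only, known or untested is meant among the compounds shown, and "the series" means these compounds.

Compound 1 `Cc1nnc(-c2nn(-c3ccccc3)c(-c3ccccc3)c2C#N)c2cn(-c3ccccc3)nc12`: > 100000 nM (a limit)
Compound 2 `N#Cc1c(-c2nnc(O)c3nn(-c4ccccc4)cc23)nn(-c2ccccc2)c1-c1ccccc1`: 21800 nM
Compound 3 `N#Cc1c(-c2nnc(-c3ccccc3)c3nn(-c4ccccc4)cc23)nn(-c2ccccc2)c1-c1ccccc1`: not yet measured

For the measured compounds named here, in a functional assay on MDA-MB-435 cells (Homo sapiens) for inhibition, read by sulforhodamine B assay, with a stated time of 48 h (a lower number here means a stronger inhibitor of growth, a higher number a weaker inhibitor of growth), compound 2 stands at 21800 nM, the only exact number so far. The result for compound 1 is a limit. Compound 3 differs by phenyl in place of hydroxy on an aromatic carbon. Going by the values given here, the only measured step bearing on this is an at least 4.5-fold lower number from compound 1 to compound 2 (0.66 log units; beyond the scatter), which came with hydroxy in place of methyl. Losing that hydroxy suggests a modest move towards a higher number in this assay, though one step gives weak guidance. The expected step is a 1.6-fold higher number from compound 2 to compound 3 (0.21 log units; within the scatter). The estimated value for compound 3 is 35000 nM, with an expected range of 10000 nM to 100000 nM.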

Compound 3, concentration for 50% growth inhibition: 31800 nM
Estimate against measurement, compound 3: 1.1-fold (0.04 log units) above; measured number inside the range.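

In this assay, six carbon atoms and a ring can replace the single oxygen of hydroxy at this position, and the hydrogen-bond donor and acceptor can leave, with a 1.5-fold higher number from compound 2 to compound 3 (0.16 log units; within the scatter). Phenyl in place of methyl gives an at least 3.1-fold lower number from compound 1 to compound 3 (0.49 log units; beyond the scatter), so phenyl and hydroxy both part from methyl but not from each other. The reading for compound 1 is a limit: the limit of > 100000 nM in this assay, at which 1 of the 3 values shown sits.

Still open, on these data alone, is whether an amine or a carboxylic acid at this position would move the number beyond the scatter from compound 2. Also open, as far as these compounds go, is whether replacing the nitrile on the shared core with a carboxamide would do so.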